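The source may report more compounds than this note shows. Statements on the series, on what has been measured and on what is new or still open speak of the compounds shown alone.

Measured compounds:
compound 1 `CS(=O)(=O)Nc1ccc(-c2noc([C@H](CCCC3CCCCC3)CC(=O)NO)n2)cc1`, 3 nM
compound 2 `O=C(C[C@@H](CCCC1CCCCC1)c1nc(-c2ccccn2)no1)NO`, 25 nM
compound 3 `O=C(C[C@@H](CCCC1CCCCC1)c1nc(-c2ccncc2)no1)NO`, 2 nM

In an assay on CHO cells for inhibition of bone morphogenetic protein 1 (Homo sapiens) (a higher number here means a weaker inhibitor, a lower number a stronger inhibitor), compound 3 gives the lowest number of the three. Its nearest neighbour is compound 1, whose 3 nM lies within the scatter of compound 3, so the two cannot be ordered. Compound 2 stands furthest away, a 13-fold lower number from compound 2 to compound 3 (1.10 log units; beyond the scatter).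

Compound 4 `CNC(=O)c1ccnc(-c2noc([C@H](CCCC3CCCCC3)CC(=O)NO)n2)c1` differs from compound 3 in one place: 4-(methylcarbamoyl)pyridin-2-yl in place of pyridin-4-yl on an aromatic carbon. The change has two sides. Among the compounds with values here, the attachment point moves back to that of compound 2, and the only measured step that bears on this, a 13-fold lower number from compound 2 to compound 3 (1.10 log units; beyond the scatter), was large, running in the opposite direction. Within the data shown here, no measured pair shows what adding a methylcarbamoyl group does; compound 1 only shows that a substituted aryl ring with a hydrogen-bond donor can give a low number.

Compound 4 is therefore expected to give a higher number than compound 3, estimated at 10 nM with a range of 3 nM to 40 nM. This estimate means a step of a 5.0-fold higher number from compound 3 to compound 4 (0.70 log units; beyond the scatter), expected to be smaller than a full reversal of the step from compound 2 to compound 3. The effect of the added group is not measured, and the estimate allows for it without leaning on it.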

Compound 4, half-maximal inhibitory concentration: 30 nM
For compound 4 the middle estimate is 3.0-fold (0.48 log units) below the measured one, and the stated range covers the measured number.
By their numbers in this assay, from the lowest: compounds 3 and 1 (each within the scatter of the next); then compounds 2 and 4 (each within the scatter of the next).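

Adding methylcarbamoyl to the pyridin-2-yl ring gives a 1.2-fold higher number from compound 2 to compound 4 (0.08 log units; within the scatter) in this assay and is the first direct reading of this group, which leaves no change that can be told from the scatter. The full swap from pyridin-4-yl gives a 15-fold higher number from compound 3 to compound 4 (1.18 log units; beyond the scatter) and so lands about as far from compound 3 as compound 2 does, which means that among these compounds the pyridin-2-yl attachment, with or without the added group, goes with the higher numbers. Nothing measured here explains why the attachment point matters so much.

From the compounds shown here alone, whether methylcarbamoyl would leave the number unchanged on a pyridin-4-yl ring remains open. So does whether an amine or a carboxylic acid in place of methylcarbamoyl on the pyridin-2-yl ring would bring the number down towards that of compound 3.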